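The source may hold more compounds than are shown below. What is called first, only, known or untested is meant among the compounds shown, and "the series" means these compounds.

Measured compounds:

compound 1, `O=C(NCCCCc1ccccc1)n1c(=O)oc2cc(Br)ccc21`: 31 nM
compound 2, `O=C(NCCCCc1ccccc1)n1c(=O)oc2ccc(Br)cc21`: 22 nM
compound 3, `O=C(NCCCCc1ccccc1)n1c(=O)oc2cc(F)ccc21`: 31 nM

All three were tested in an assay on HEK293 cells for inhibition of acid ceramidase (Homo sapiens), with a stated time of 10 min; on this read-out lower numbers stand for stronger inhibition and higher numbers for weaker inhibition. Compound 1 and compound 2 are built from the same atoms joined differently; the difference between the two cores is not broken down here. Compound 3 is made from compound 1 by one change, (fluoro in place of bromo on an aromatic carbon), and the measured step was no change at the digits printed from compound 1 to compound 3 (within the scatter). Compound 4, `O=C(NCCCCc1ccccc1)n1c(=O)oc2ccc(F)cc21`, has not yet been measured; it is made from compound 2 by the same change, (fluoro in place of bromo on an aromatic carbon), and the surroundings of the place where the change happens read the same for both pairs. Because the same change gave no change at the digits printed from compound 1 to compound 3 (within the scatter), compound 4 is expected to land close to compound 2. The expected step is a 1.1-fold higher number from compound 2 to compound 4 (0.04 log units; within the scatter), set beside the measured no change at the digits printed from compound 1 to compound 3 (within the scatter). This expectation rests on a single measured pair, so the range is kept fairly wide. Compound 4 is estimated at 24 nM in this assay, between 10 nM and 55 nM.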

Compound 4, half-maximal inhibitory concentration: 12 nM
Estimate against measurement, compound 4: 2.0-fold (0.30 log units) above; the measured number falls inside the stated range.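

In this assay, putting fluoro in place of bromo on the core of compound 2 gives a 1.8-fold lower number from compound 2 to compound 4 (0.26 log units; within the scatter). Set beside the same change on the core of compound 1, the two steps cannot be told apart: the same change on two cores in this assay, no change at the digits printed (within the scatter) from compound 1 to compound 3 and a 1.8-fold lower number (0.26 log units; within the scatter) from compound 2 to compound 4, 1.8-fold (0.26 log units) apart, within the scatter of two such steps. So in these two pairs the change carries from one core to the other without a difference that stands clear of the ordinary spread of repeat measurements, but this does not show that fluoro and bromo truly differ on either core, nor that the agreement would hold on any further core.

The compounds shown hold only these two halogens, so it remains open whether a chloro group, a methoxy group or an amine on the same aromatic carbon would behave like them on both cores. Going by these compounds alone, it is also open whether the agreement would survive with a shorter chain in place of the one all four compounds share.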